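This account rests on a few compounds, and the source may have more. Where it says the series, first, only, none or still open, it means among the compounds named here.

Compound 1 `CC1=CC[C@H](C(C)(C)NC(=S)N/N=C/c2ccc(O)cc2)CC1` is the starting point here. In a functional assay on NCI-H460 cells (Homo sapiens) for inhibition, read by sulforhodamine B assay, with a stated time of 48 h (a lower number here means a stronger inhibitor of growth, a higher number a weaker inhibitor of growth), compound 1 gives only > 100000 nM, which is a limit of the assay and not a number. Compound 2 `COc1cc(/C=N/NC(=S)NC(C)(C)[C@H]2CC=C(C)CC2)ccc1O` likewise gives only > 100000 nM in this assay, again a limit. The step that the two limits leave unreadable from compound 1 to compound 2 is thus not readable, as the limit of > 100000 nM in this assay, at which 2 of the 2 values shown sit, shows. Compound 3 `CC1=CC[C@H](C(C)(C)NC(=S)N/N=C/c2ccc[nH]2)CC1` differs from compound 1 by 1H-pyrrol-2-yl in place of 4-hydroxyphenyl on a carbon with a double bond to nitrogen. For the measured compounds named here, no measured step bears on this change; the only recorded step is unreadable. Compound 3 is therefore expected to sit at the limit as well, the step of a number no higher from compound 1 to compound 3 (the limit leaves the size open) being estimated as no readable change, with an estimate of 100000 nM in the range 30000 nM to 300000 nM.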

Compound 3, concentration for 50% growth inhibition: 18000 nM
For compound 3 the middle estimate is 5.6-fold (0.74 log units) above the measured one, outside the stated range (below it).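

Changing the group on a carbon with a double bond to nitrogen moves the series off the limit in this assay: 1H-pyrrol-2-yl in place of 4-hydroxyphenyl gives an at least 5.5-fold lower number from compound 1 to compound 3 (0.74 log units; beyond the scatter). This position therefore affects the read-out, which the unreadable methoxy step could not show. The true size of the step stays open, since compound 1 gives only a limit: the limit of > 100000 nM in this assay, at which 2 of the 3 values shown sit.

The compounds shown leave open whether the ring hydrogen of 1H-pyrrol-2-yl matters, which a 1-methylpyrrol-2-yl group would test. They also leave open whether a furan-2-yl or pyridin-2-yl group would serve equally at this place.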